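A few compounds are considered here, and "the series" means these few. Any claim that something is new, unique, unknown or untested is made for them only; others in the source may bear on it.

Measured so far in a functional assay on U-251 cells (Homo sapiens) for inhibition, read by sulforhodamine B assay, with a stated time of 48 h; on this read-out lower numbers stand for stronger inhibition of growth and higher numbers for weaker inhibition of growth:
- compound 1 `CC1=CC[C@H](C(C)(C)NC(=S)N/N=C/c2ccccc2)CC1`: 71400 nM
- compound 2 `COc1ccc(/C=N/NC(=S)NC(C)(C)[C@H]2CC=C(C)CC2)cc1`: 71900 nM
- compound 3 `CC1=CC[C@H](C(C)(C)NC(=S)N/N=C(\C)c2ccccc2)CC1`: > 100000 nM

Compound 1 gives 71400 nM and compound 2 gives 71900 nM in this assay. The change between them is methoxy in place of hydrogen on an aromatic carbon, and it made a 1.0-fold higher number from compound 1 to compound 2 (0.00 log units; within the scatter). For compound 3 the number is a limit of the assay, not a measured value: > 100000 nM. That is the limit of > 100000 nM in this assay, at which 1 of the 3 values shown sits. How the core of compound 3 differs from the core of compound 1 is not broken down here.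

Compound 4 `COc1ccc(/C(C)=N/NC(=S)NC(C)(C)[C@H]2CC=C(C)CC2)cc1` is not yet measured. It differs from compound 3 by methoxy in place of hydrogen on an aromatic carbon, the same change as from compound 1 to compound 2, at the same place. Since the measured step of a 1.0-fold higher number from compound 1 to compound 2 (0.00 log units; within the scatter) lies within the scatter, a step that the limit leaves unreadable from compound 3 to compound 4 is expected here as well. Compound 4 is estimated at 150000 nM in this assay, likely reported again only as a limit, with an expected range from 70000 nM to 400000 nM.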

Compound 4, concentration for total growth inhibition: > 100000 nM
Compound 4 gave a limit, no number; the forecaster's own chance of this, stated with the estimate: 75%; the middle value does not contradict the limit.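

No step can be read from compound 3 to compound 4: in this assay, both give only a limit of the assay, not a number. The compounds shown leave open what methoxy in place of hydrogen does on the core of compound 3.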